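The source may hold more compounds than are shown below. What is called first, only, known or untested is meant among the compounds shown, and "the series" means these compounds.

Working notes on the series in an assay on nucleic acid for inhibition of Nucleic Acid, read by fluorescence, tested at 100 uM; a higher number here means more inhibition at the concentration tested (going by the name of the read-out), a lower number less inhibition. Compound 1 `CC(C)CCN(C)Cc1cn(CC(O)COC(=O)c2ccccc2)nn1` gives 0% in this assay. Among the compounds with values here, compound 2 `O=C(NCc1ccccc1)OCC(O)Cn1cc(CN2CCC(c3ccccc3)CC2)nn1` gives 29% in this assay, the higher of the two numbers measured so far; its only neighbour is compound 1, and the gap between them lies beyond the scatter. Within the data shown here, no pair of measured compounds differs in a single place, so no measured step is available to read from.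

Compound 3 `CCCCC(O)Cn1cc(CN2CCC(c3ccccc3)CC2)nn1` is not yet measured. It differs from compound 2 as follows: propyl in place of (benzylcarbamoyl)oxy on a saturated chain carbon, two bonds along the chain from an oxygen on a saturated carbon. The part that leaves carries the only aromatic ring and both hydrogen-bond acceptors of that end of the chain, while the part that enters carries none. Among the measured compounds shown here, with no measured step of this kind to lean on, a downward step beyond the scatter is expected, though the sparse data leave wide uncertainty. The step from the measurement of compound 2 that this expectation means is a number 17 percentage points lower from compound 2 to compound 3 (beyond the scatter). Compound 3 is accordingly estimated at 12%, with a range from 0% to 30%.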

Compound 3, a percentage reported as inhibition, at one concentration (the size of the read-out at that concentration, not a potency): 16%
The estimate for compound 3 lay 4 percentage points below the measured number; measured number inside the range.
By their numbers in this assay, from the lowest: compound 1; then compound 3; then compound 2.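

In this assay, within the data shown here, the first measured step at this position is a number 13 percentage points lower from compound 2 to compound 3 (beyond the scatter) when propyl takes the place of (benzylcarbamoyl)oxy on a saturated chain carbon, two bonds along the chain from an oxygen on a saturated carbon. The drop is real but partial: compound 3 still gives 16% without the six-membered aromatic ring or the hydrogen-bond donor and acceptors of the group that leaves, so the (benzylcarbamoyl)oxy group is not needed for a measurable reading in this series. No measurement at hand accounts for the size of this step.

The compounds shown do not separate the contribution of the aromatic ring from that of the carbamate link. A benzyl ether or a longer chain such as octyl at this carbon would bear on that question.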